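A few compounds are considered here, and "the series" means these few. Any claim that something is new, unique, unknown or untested is made for them only; others in the source may bear on it.

Compound 1 `O=C(CCCCCCC(=O)Nc1cccc(C(F)(F)F)c1)NO`: 1200 nM
Compound 2 `O=C(CCCCCCC(=O)Nc1ccc(Cl)cc1)NO`: 550 nM

In a functional assay on U-937 cells (Homo sapiens) for antiproliferative activity, with a stated time of 48 h (a lower number here means that less compound is needed, a higher number that more compound is needed for the effect), compound 2 gives 550 nM, the lower of the two numbers, and its gap to compound 1 lies just beyond the scatter. Compound 3 `O=C(CCCCCCC(=O)Nc1ccc([N+](=O)[O-])cc1)NO` carries nitro in place of chloro on an aromatic carbon, para to a large group (nitro in place of chloro on an aromatic carbon). For the measured compounds named here, no measured step shows what this exchange does. The two ring-substituted compounds do, however, stay close, with compound 1 at 1200 nM and compound 2 at 550 nM, so only a small change is expected. The estimated step is a 1.2-fold higher number from compound 2 to compound 3 (0.07 log units; within the scatter), which is not expected to go beyond the scatter. For compound 3 the estimated value is 650 nM, with an expected range from 250 nM to 1500 nM.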

Compound 3, half-maximal effective concentration: 22000 nM
Compound 3: middle estimate off by 34-fold (1.53 log units), on the low side; the measured number lies above the stated range.
By their numbers in this assay, from the lowest: compound 2; then compound 1; then compound 3.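

In this assay, the substituent on this aromatic carbon, para to a large group, proves decisive: nitro in place of chloro gives a 40-fold higher number from compound 2 to compound 3 (1.60 log units; beyond the scatter), the first single-place change shown. So the small gap between the two earlier compounds did not mean that this position tolerates any group. Nothing given here bears on why the number rises so far. The compounds shown leave open whether an amine or a methoxy group here would stay near compound 2 or move towards compound 3. They also leave open whether nitro would act alike elsewhere on the ring.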